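Substance-K receptor series: pyrimidinyl in place of cyanopropyl

The source may hold more compounds than are shown below. What is called first, only, known or untested is meant among the compounds shown, and "the series" means these compounds.

Measured so far:
compound 1 `N#CCN(Cc1ccc(CCc2ccccc2)cc1)Cc1ccc2ccccc2c1` — 20%
compound 2 `N#CCN(Cc1ccccc1)Cc1cccc(Cl)c1` — 0%
compound 3 `N#CCCCN(Cc1ccccc1)Cc1ccc2ccccc2c1` — 0%

In an assay on HEK293 cells for binding affinity to Substance-K receptor (Rattus norvegicus), read by FRET, tested at 10 uM (a higher number here means more inhibition at the concentration tested (going by the name of the read-out), a lower number less inhibition), compound 3 gives 0%, level at the digits shown with compound 2, which gives 0%; together these two are the lowest of the three numbers. Compound 1, with 20%, stands above compound 3 by a margin beyond the scatter, and the two structures differ in several places at once, so nothing is drawn from that gap for the step below.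

Compound 4 `c1ccc(CN(Cc2ccc3ccccc3c2)c2ccncn2)cc1` is not yet measured in this assay. Relative to compound 3 the change is pyrimidin-4-yl in place of 3-cyanopropyl on an amine nitrogen. The remaining parts of the molecule are the same as in compound 3.

Going by the values given here, no step between measured compounds matches this change, so its size is unknown. What is known is that compound 3 and compound 2 give the lowest readings of the set, and the change does not repeat any difference seen between them and compound 1. A small step upward or none beyond the scatter is expected in this assay, with a number 8 percentage points higher from compound 3 to compound 4 (within the scatter) as the expected step from compound 3 to compound 4. Compound 4 is estimated at 8%, in the range 0% to 30%.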

Compound 4, a percentage reported as inhibition, at one concentration (the size of the read-out at that concentration, not a potency): 34%
Compound 4: the middle estimate sits 26 percentage points below what was measured; measured number outside the range, above it.
By their numbers in this assay, from the lowest: compounds 2 and 3 (each within the scatter of the next); then compound 1; then compound 4.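

Going by these compounds alone, on the amine nitrogen, this is the first place where a single change can be read: in this assay pyrimidin-4-yl in place of 3-cyanopropyl gives a number 34 percentage points higher from compound 3 to compound 4 (beyond the scatter) with the rest of the molecule unchanged. The earlier compounds shown here differ from one another in several places at once, so they could not tie a reading to any one group, whereas this pair shows that the group on this nitrogen can move the reading and that a six-membered aromatic ring with 2 hetero atoms is compatible with inhibition at the concentration tested. No measurement at hand explains the step, which is a difference in readings at one concentration and not in potency.

As far as these compounds go, it remains open whether the step belongs to the aromatic ring as such or to its ring nitrogens, a question that phenyl, pyridin-4-yl or pyrimidin-2-yl on the same amine nitrogen could separate. From the compounds shown here alone, it also rests on a single pair, so whether pyrimidin-4-yl has a similar effect with other groups on that nitrogen, such as the 4-(2-phenylethyl)benzyl group of compound 1, is unknown.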